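The compounds below may be only part of what the source reports. "The series", "measured", "known", "first", "only" and "open" are said of these compounds alone.

Three compounds built from two linked five-membered rings carrying an amidine have been tested in an ADME assay on cells (Erythrocyte, Homo sapiens) for activation, read by hemolysis, with a stated time of 30 min, tested at 10 mM; on this read-out higher numbers stand for a stronger effect at the one concentration tested and lower numbers for a weaker effect. Compound 1 `N=C(N)c1ccc(-c2ccc(-c3ccccc3)s2)s1` gives 85.1%. Compound 2 `COc1ccc(-c2ccc(-c3ccc(C(=N)N)o3)o2)cc1` gives 71.7%. Compound 3 `COc1cccc(-c2ccc(-c3ccc(C(=N)N)s3)s2)c1` gives 79%, and the numbers for compound 2 and compound 3 lie within the usual scatter of each other, so neither can be called stronger. The difference between the cores of compound 2 and compound 3 is not broken down here.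

Compound 3 and compound 1 differ in one place: hydrogen in place of methoxy on an aromatic carbon. This gave a number 6.1 percentage points higher from compound 3 to compound 1 (within the scatter) in this assay.

Compound 4 `N=C(N)c1ccc(-c2ccc(-c3ccccc3)o2)o1` is not yet measured. It differs from compound 2 by the same kind of change, (hydrogen in place of methoxy on an aromatic carbon), though here the group sits para to a large group, whereas in the earlier pair it sat meta to a large group.

Because the earlier step of a number 6.1 percentage points higher from compound 3 to compound 1 (within the scatter) was small, a similarly small step a number 5.3 percentage points higher from compound 2 to compound 4 (within the scatter) is expected on the other core. Compound 4 is therefore estimated at 77%, between 62% and 90%.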

Compound 4, a percentage reported as activity, at one concentration (the size of the read-out at that concentration, not a potency): 66.7%
Estimate against measurement, compound 4: 10.3 percentage points above, and the stated range covers the measured number.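

On the core of compound 2, hydrogen in place of methoxy gives a number 5 percentage points lower from compound 2 to compound 4 (within the scatter) in this assay. Set beside the same change on the core of compound 1, the two steps point in opposite directions on paper, yet they cannot be told apart: the same change on two cores in this assay, a number 6.1 percentage points higher (within the scatter) from compound 3 to compound 1 and a number 5 percentage points lower (within the scatter) from compound 2 to compound 4, 11.1 percentage points apart, within the scatter of two such steps What this shows is that, in these two pairs, the change stays within the scatter on both cores, so the opposite signs are no evidence that the cores respond differently, while it does not show that the change is without effect on other cores or that the two cores truly respond alike, as each core offers only a single pair, read at one concentration.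

The compounds shown leave open whether a different group at this place on the six-membered ring, such as an amine or a carboxylic acid, would give a step beyond the scatter. Among these compounds, they also leave open what the core alone contributes, as no pair here differs only in its core.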